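The source may hold more compounds than are shown below. What is called first, only, known or untested is meant among the compounds shown, and "the series" means these compounds.

In a functional assay on HT-29 cells (Homo sapiens) for cytotoxicity, read by MTT assay, with a stated time of 72 h (on this read-out higher numbers stand for lower toxicity in this test and lower numbers for higher toxicity in this test), two compounds have been measured so far. Compound 1 `N#C[Se]c1ccc(NC(=O)Oc2ccc(F)cc2)cc1` gives 66500 nM, and compound 2 `O=C(Nc1ccc([Se][Se]c2ccc(NC(=O)OCc3ccc([N+](=O)[O-])cc3)cc2)cc1)OCc1ccc([N+](=O)[O-])cc1` gives 75900 nM; the number for compound 1 sits close to that of compound 2, and the two lie within the usual scatter of each other. Compound 3 `N#C[Se]c1ccc(NC(=O)Oc2ccccc2)cc1` differs from compound 1 in a single place: hydrogen in place of fluoro on an aromatic carbon. Within the data shown here, no measured pair shows what such a change does in this test, so the expected step of no change at the digits printed from compound 1 to compound 3 (within the scatter) is none beyond the scatter. Compound 3 is thus estimated at 66500 nM, with a range from 30000 nM to 150000 nM.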

Compound 3, concentration lethal to 50% of the cells: 71700 nM
Compound 3: middle estimate off by 1.1-fold (0.03 log units), on the low side; measured number inside the range.
By their numbers in this assay, from the lowest: compounds 1, 3 and 2 (each within the scatter of the next).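

In this assay, hydrogen in place of fluoro on an aromatic carbon, para to a large group, gives a 1.1-fold higher number from compound 1 to compound 3 (0.03 log units; within the scatter), a step within the scatter. This first pair therefore shows that fluoro and hydrogen at this place cannot be told apart in this test. No supporting measurement is available to explain this result.

From the compounds shown here alone, what an amine, a methoxy group or a carboxylic acid on this same carbon would do remains open. So does whether any group at this place can move the number beyond the scatter.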